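The compounds below may be only part of what the source reports. "The series", "measured", "known", "first", "only" and "open" are said of these compounds alone.

Working notes on the series.

The core with one 3,5-dihydroxyphenyl ring is represented by compound 1 `O=C1OC(c2cc(O)cc(O)c2)C(c2ccc(O)cc2)=C1O`; in a functional assay on PC-3 cells (Homo sapiens) for antiproliferative activity, read by MTT assay, with a stated time of 72 h, tested at 10 uM (a higher number here means more inhibition at the concentration tested (going by the name of the read-out), a lower number less inhibition), compound 1 gives 39%. Compound 2 `O=C1OC(c2ccc(O)cc2)C(c2ccc(O)cc2)=C1O` carries a 4-hydroxyphenyl ring at that position instead, and in this assay compound 2 gives 0%. The difference between the two cores is not broken down here. Among the compounds with values here, compound 3 `O=C1OC(c2ccc(O)cc2)C(c2ccc(F)cc2)=C1O` differs from compound 2 by fluoro in place of hydroxy on an aromatic carbon, and in this assay compound 3 gives 31%; the step of a number 31 percentage points higher from compound 2 to compound 3 (beyond the scatter) is the only measured instance of this change.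

Compound 4 `O=C1OC(c2cc(O)cc(O)c2)C(c2ccc(F)cc2)=C1O`, not yet measured, differs from compound 1 by fluoro in place of hydroxy on an aromatic carbon; the place is described in the same words for both pairs, so it is the same change made on the other core. The expectation rests on compound 2 and compound 3, because a number 31 percentage points higher from compound 2 to compound 3 (beyond the scatter) was large, and on compound 1, which starts from 39%. Compound 4 is therefore expected to reach 62% in this assay, an estimated step of a number 23 percentage points higher from compound 1 to compound 4 (beyond the scatter), with the estimated range from 40% to 85%.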

Compound 4, a percentage reported as inhibition, at one concentration (the size of the read-out at that concentration, not a potency): 0%
Beside the measured number, compound 4's estimate is 62 percentage points above it; measured number below the stated range.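

In this assay, on the core with the 3,5-dihydroxyphenyl ring, the change from 4-hydroxyphenyl to 4-fluorophenyl gives a number 39 percentage points lower from compound 1 to compound 4 (beyond the scatter) and runs opposite to what the same change does on the core with the 4-hydroxyphenyl ring. The result therefore does not support carrying this change from one core to the other in this series, and the effect of the change has to be read separately for each core. It does not show why the two cores part, or which of the two directions would hold on a further core, since each direction rests on a single pair of compounds read at one concentration: the same change on two cores in this assay, a number 31 percentage points higher (beyond the scatter) from compound 2 to compound 3 and a number 39 percentage points lower (beyond the scatter) from compound 1 to compound 4, 70 percentage points apart, beyond the scatter of two such steps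

What the compounds shown leave open is whether a group such as chloro, methoxy or an amine in place of the fluoro would also behave differently on the two cores. Also open, on these data alone, is how these pairs would compare at other concentrations; each compound here has a single inhibition value at one concentration.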